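Acid to methylamide step on two related cores

The source may report more compounds than this note shows. Statements on the series, on what has been measured and on what is new or still open speak of the compounds shown alone.

Working notes on a small set of pyridine-linked vinyl acids and amides, all tested in a functional assay on MCF7 cells (Homo sapiens) for inhibition, read by sulforhodamine B assay, with a stated time of 72 h; on this read-out lower numbers stand for stronger inhibition of growth and higher numbers for weaker inhibition of growth. Compound 1 `CNC(=O)/C=C/c1ccncc1-c1ccc2ccccc2c1` gives 9340 nM in this assay. Compound 2 `O=C(O)/C=C/c1ccncc1-c1ccc2ccccc2c1` reaches only the limit of this assay, > 10000 nM. Compound 3 `Cn1ccc2cc(-c3cnccc3/C=C/C(=O)O)ccc21` likewise gives only the limit of this assay, > 10000 nM. The cores of compound 2 and compound 3 are not the same; the difference between the two cores is not broken down here. Compound 4 `CNC(=O)/C=C/c1ccncc1-c1ccc2c(ccn2C)c1` is not yet measured.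

For the measured compounds named here, the one change made and measured is methylamino in place of hydroxy on a carbonyl carbon, which yields an at least 1.0-fold lower number from compound 2 to compound 1 (0.02 log units; that floor lies within the scatter). Since (the limit of > 10000 nM in this assay, at which 2 of the 3 values shown sit), this step is known only as a floor, and the true size is open. The change planned for the second pair, (methylamino in place of hydroxy on a carbonyl carbon), is the same change at the same place, so the pair of compound 3 and compound 4 can be read against the pair of compound 2 and compound 1.

For compound 4 the step of an at least 1.1-fold lower number from compound 3 to compound 4 (0.04 log units; that floor lies within the scatter) is expected, resting on an at least 1.0-fold lower number from compound 2 to compound 1 (0.02 log units; that floor lies within the scatter) and on (the limit of > 10000 nM in this assay, at which 2 of the 3 values shown sit), which together leave room for anything from no gain to a modest one. Compound 4 is thus estimated at 9000 nM in this assay, with the spread 3000 nM to 30000 nM, and a real chance that only a limit is reported.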

Compound 4, concentration for 50% growth inhibition: 7120 nM
Compound 4: the middle estimate sits 1.3-fold (0.10 log units) above what was measured; low and high end bracket the measured number.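

In this assay, the replacement of hydroxy by methylamino on the carbonyl carbon of the second core gives an at least 1.4-fold lower number from compound 3 to compound 4 (0.14 log units; that floor lies within the scatter), and the two pairs can be set side by side only as floors: the same change on two cores in this assay, an at least 1.0-fold lower number (0.02 log units; that floor lies within the scatter) from compound 2 to compound 1 and an at least 1.4-fold lower number (0.14 log units; that floor lies within the scatter) from compound 3 to compound 4; the limit leaves it open whether they differ On each core the amide, compound 1 and compound 4, reads as a number and the acid, compound 2 and compound 3, reads as a limit, so the change carries over in that limited sense, but neither step is shown to be a real gain and no size is shown to transfer from one core to the other. The true size of either step stays hidden at the top of the measurable range: the limit of > 10000 nM in this assay, at which 2 of the 4 values shown sit.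

The compounds shown leave open whether a different group on the carbonyl carbon, such as a primary amide, a dimethylamide, a methyl ester or a longer chain on the amide nitrogen, would give a clearer step on either core. They also leave open what the core itself contributes, since the pairs differ in more than one place and only the change from carboxy to methylcarbamoyl can be read within each core.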